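The compounds below may be only part of what the source reports. "The series", "measured", "known", "first", "only" and "open" are said of these compounds alone.

Measured so far:
compound 1 `N#CC1=C(N)Oc2c(c3nc4ccccc4nc3c3ccccc23)C12C(=O)N(Cc1cnnn1-c1cccc(Cl)c1)c1ccccc12` — > 50000 nM in an ADME assay on HUVEC cells (Homo sapiens) for antiproliferative activity, read by MTT assay, with a stated time of 48 h; a lower number here means a stronger inhibitor, a higher number a weaker inhibitor
compound 2 `N#CC1=C(N)Oc2c(c3nc4ccccc4nc3c3ccccc23)C12C(=O)N(Cc1cnnn1-c1ccccc1Br)c1ccccc12` — > 50000 nM
compound 3 `CC(=O)Nc1ccc(-n2nncc2CN2C(=O)C3(C(C#N)=C(N)Oc4c(N)cc5nc6ccccc6nc5c43)c3ccccc32)cc1` — > 50000 nM

Each of these three values is a limit of the assay, not a number. Compound 3 therefore stands where every value in the series stands: the limit of > 50000 nM in this assay, at which 3 of the 3 values shown sit. Within the data shown here, the one measured step between neighbours that differ in a single place, a step that the two limits leave unreadable from compound 1 to compound 2, runs from one limit to another, and its size cannot be read.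

The next compound, compound 4 `N#CC1=C(N)Oc2c(N)cc3nc4ccccc4nc3c2C12C(=O)N(Cc1cnnn1-c1ccc([N+](=O)[O-])cc1[N+](=O)[O-])c1ccccc12`, differs from compound 3 by 2,4-dinitrophenyl in place of 4-acetamidophenyl on an aromatic nitrogen. Among the measured compounds shown here, no measured step touches a change of the group on this aromatic nitrogen with a readable size, so the only guide is that all three measured compounds sit at the limit. Compound 4 is expected to give 50000 nM, within 20000 nM to 100000 nM. The step of a number no higher from compound 3 to compound 4 (the limit leaves the size open) is expected to be none beyond the scatter, with a further limit value the most likely outcome.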

Compound 4, half-maximal inhibitory concentration: > 50000 nM
Compound 4 was reported as a limit; the forecaster's own chance of this, stated with the estimate: 85%; the middle value lies on the limit itself.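

In this assay compound 4 gives > 50000 nM, which is a limit of the assay. The step from compound 3 to compound 4 runs between two limits and cannot be read. The compounds shown leave open how far any change of the group on this aromatic nitrogen moves the value, since every value shown sits at one point: the limit of > 50000 nM in this assay, at which 4 of the 4 values shown sit.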